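This account rests on a few compounds, and the source may have more. Where it says the series, first, only, none or still open, it means among the compounds named here.

Compound 2 `Cc1ccccc1-n1c(Nc2nc(-c3ccc(Cl)cc3)cs2)n[nH]c1=S` gives 100 mg/kg in a functional assay on the whole organism (strain Swiss albino) for inhibition, with Mus musculus as the target, with a stated time of 0.5 h (on this read-out lower numbers stand for an effect already at smaller amounts and higher numbers for an effect only at larger amounts of compound), level with compound 1 `Cc1ccccc1-n1c(Nc2nc(-c3ccccc3)cs2)n[nH]c1=S`, which gives 100 mg/kg in the same assay. Among the measured compounds shown here, the single step measured so far, no change at the digits printed from compound 1 to compound 2 (within the scatter), a chloro in place of hydrogen on an aromatic carbon, produced nothing beyond the scatter. Compound 3 `Cc1ccccc1-n1c(Nc2nc(-c3ccc(Br)cc3)cs2)n[nH]c1=S` differs from compound 2 by bromo in place of chloro on an aromatic carbon, namely 4-chlorophenyl to 4-bromophenyl. That earlier step bears only loosely on this one, yet with no movement seen there, no step beyond the scatter is expected for compound 3 in this assay. The estimate for compound 3 is 100 mg/kg, spanning 50 mg/kg to 200 mg/kg. This expectation amounts to no change at the digits printed from compound 2 to compound 3 (within the scatter).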

Compound 3, minimum effective dose: 30 mg/kg
Estimate against measurement, compound 3: 3.3-fold (0.52 log units) above; the whole stated range lies above it.
By their numbers in this assay, from the lowest: compound 3; then compounds 1 and 2 (each within the scatter of the next).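

In this assay this place, para to a large group, is no longer silent: bromo in place of chloro gives a 3.3-fold lower number from compound 2 to compound 3 (0.52 log units; beyond the scatter) and bromo in place of hydrogen gives a 3.3-fold lower number from compound 1 to compound 3 (0.52 log units; beyond the scatter) here. A halogen at this place can therefore shift the dose, but chloro goes against any general halogen pattern, and only bromo does so among these compounds. Nothing shown here explains the difference between bromo and chloro. As far as these compounds go, whether iodo, a methoxy group or an amine at the same place would lower the number further remains open.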